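This account rests on a few compounds, and the source may have more. Where it says the series, first, only, none or still open, it means among the compounds named here.

In a functional assay on HCT-116 cells (Homo sapiens) for antiproliferative activity, read by MTT assay, with a stated time of 72 h (a higher number here means a weaker inhibitor, a lower number a stronger inhibitor), the measured compounds give these values.
Compound 1 `COc1cc(OC)cc(-c2cccc(NC(=O)CCc3cccc4c3B(O)OC4)c2)c1` gives 53 nM
Compound 2 `O=C(CCc1cccc2c1B(O)OC2)Nc1cccc(-c2cccc(OC(F)(F)F)c2)c1` gives 310 nM
Compound 3 `CSc1cccc(-c2cccc(NC(=O)CCc3cccc4c3B(O)OC4)c2)c1` gives 110 nM

Compound 3 holds the middle place among these three numbers, higher than compound 1 and lower than compound 2. Compound 4 `N#Cc1cccc(-c2cccc(NC(=O)CCc3cccc4c3B(O)OC4)c2)c1` differs from it in one place, with cyano in place of methylsulfanyl on an aromatic carbon, meta to a large group (cyano in place of methylsulfanyl on an aromatic carbon). For the measured compounds named here, two measured steps bear on this change: the swap of the same substituent (a 2.8-fold lower number from compound 2 to compound 3 (0.45 log units; beyond the scatter)) and the change of the whole aryl group (a 2.1-fold higher number from compound 1 to compound 3 (0.32 log units; beyond the scatter)). Both are modest, so a modest step is expected in this assay as well, leaning slightly towards a higher number, though the data do not settle its direction. The expected step is (a 1.5-fold higher number from compound 3 to compound 4 (0.16 log units; within the scatter)). Compound 4 is estimated at 160 nM (range 60 nM to 420 nM).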

Compound 4, half-maximal inhibitory concentration: 140 nM
Compound 4: middle estimate off by 1.1-fold (0.06 log units), on the high side, within the range that was stated.
By their numbers in this assay, from the lowest: compound 1; then compounds 3 and 4 (each within the scatter of the next); then compound 2.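

In this assay, cyano and methylsulfanyl on this aromatic carbon cannot be told apart (a 1.3-fold higher number from compound 3 to compound 4 (0.10 log units; within the scatter)), so the two small groups give a similar reading despite their different atoms. Cyano still stands apart from trifluoromethoxy (a 2.2-fold lower number from compound 2 to compound 4 (0.35 log units; beyond the scatter)), and the 3-cyanophenyl group does not match the 3,5-dimethoxyphenyl group (a 2.6-fold higher number from compound 1 to compound 4 (0.42 log units; beyond the scatter)). No measurement here accounts for these steps. The compounds shown leave open how an amine or a carboxylic acid on this aromatic carbon would compare.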